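Removing the cyclopropyl from an amide nitrogen

This account rests on a few compounds, and the source may have more. Where it says the series, first, only, none or still open, it means among the compounds named here.

Measured so far:
compound 1, `COc1ccc2c(c1)/C(=C/C(N)=O)CC2`: 3%
compound 2, `O=C(/C=C1\CCc2c1ccc(F)c2F)NC1CC1`: 27%
compound 3, `O=C(/C=C1\CCc2cc(F)c(F)cc21)NC1CC1`: 48%

All three numbers come from a functional assay on the whole organism with Rattus norvegicus as the target, at a dose of 20 mg/kg by the oral route; a higher number here means more inhibition at the dose given (going by the name of the read-out), a lower number less inhibition. Among them compound 2 stands second highest; its nearest neighbour is compound 3, whose number is higher by a gap beyond the scatter, and its furthest is compound 1, whose number is lower, again by a gap beyond the scatter. Compound 3 shares the cyclopropyl amide with compound 2 but carries its two fluorines elsewhere; compound 1 carries a methoxy and a plain amide. Neither pair differs in only one place, so these values show only where each compound stands, not what one change does.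

The unmeasured compound 4 is `NC(=O)/C=C1\CCc2c1ccc(F)c2F`. Relative to compound 2 it changes as follows: hydrogen in place of cyclopropyl on an amide-type nitrogen. Among the measured compounds shown here, no measured pair shows this change on its own. The only plain amide measured, compound 1, gives 3%, but its core differs too, so it is a weak hint at best. In this assay a moderate drop is expected, close to the edge of the scatter, rather than a gain. Compound 4 is expected to give 15%, with a likely range from 3% to 35%, an estimated step of a number 12 percentage points lower from compound 2 to compound 4 (beyond the scatter).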

Compound 4, a percentage reported as inhibition, in the whole organism at one dose (the size of the read-out at that dose, not a potency): 82%
The estimate for compound 4 lay 67 percentage points below the measured number; measured number above the stated range.
By their numbers in this assay, from the lowest: compound 1; then compound 2; then compound 3; then compound 4.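

On the core of compound 2, with both fluorines left as they are, the group on the amide nitrogen proves to matter a great deal in this assay: putting hydrogen in place of cyclopropyl gives a number 55 percentage points higher from compound 2 to compound 4 (beyond the scatter), a large step. Among the compounds shown here, this is the first pair in the set that differs in only one place, so the effect of this change can now be read directly instead of being inferred from compounds that also differ in their cores. For this core, the cyclopropyl is therefore not required for inhibition at the dose tested, and the unsubstituted amide carbamoyl group gives the better result; the data in hand offer no measured explanation for this step.

The compounds shown leave open whether the same change would have a similar effect with the fluorine arrangement of compound 3, since this one step comes from a single core. They also leave open where a methyl or a longer chain such as propyl on the amide nitrogen would fall relative to compound 2 and compound 4, which would show whether the effect grows gradually with the size of the group.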